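Adding a Methoxy Group to the Hydroxyphenyl Hydrazone

The source may report more compounds than this note shows. Statements on the series, on what has been measured and on what is new or still open speak of the compounds shown alone.

Compound 1, `C/C(=N\NC(=O)c1cccc(S(=O)(=O)N2CCOCC2)c1)c1ccc(F)cc1`, in a functional assay on SMMC-7721 cells (Homo sapiens) for antiproliferative activity, read by MTT assay, with a stated time of 72 h (a higher number here means a weaker inhibitor, a lower number a stronger inhibitor), gives only a limit, > 100000 nM.
Compound 2, `O=C(N/N=C/c1ccccn1)c1cccc(S(=O)(=O)N2CCOCC2)c1`, in this assay also gives only a limit, > 100000 nM.
Compound 3, `O=C(N/N=C/c1ccccc1O)c1cccc(S(=O)(=O)N2CCOCC2)c1`, in this assay gives 12100 nM.

Going by the values given here, of the three measured compounds, compound 3 is the only one with an actual number; the other two sit at the same limit, (the limit of > 100000 nM in this assay, at which 2 of the 3 values shown sit). Among the compounds with values here, the single step that can be sized is the one an at least 8.2-fold lower number from compound 2 to compound 3 (0.91 log units; beyond the scatter), which swaps the ring hanging on the carbon doubly bonded to nitrogen, and it is at least modest.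

Compound 4, `COc1ccc(/C=N/NC(=O)c2cccc(S(=O)(=O)N3CCOCC3)c2)c(O)c1`, keeps that 2-hydroxyphenyl ring and changes it in one spot: methoxy in place of hydrogen on an aromatic carbon. Within the data shown here, this is a far smaller alteration than the ring swap from compound 2 to compound 3, and no measured pair shows what a methoxy group does here. The expectation is therefore a step of a 1.3-fold lower number from compound 3 to compound 4 (0.13 log units; within the scatter) that stays within the usual scatter, with no clear direction. On that basis, compound 4 in this assay is expected to give about 9000 nM, most likely between 2500 nM and 35000 nM.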

Compound 4, half-maximal inhibitory concentration: 3950 nM
Compound 4: the middle estimate sits 2.3-fold (0.36 log units) above what was measured, within the range that was stated.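

The methoxy result shows that the 2-hydroxyphenyl ring can take a further group on an aromatic carbon, meta to the hydroxy group, and that this small change moves the result in this assay: the step is a 3.1-fold lower number from compound 3 to compound 4 (0.49 log units; beyond the scatter). Going by these compounds alone, until now, the only readable change had been the exchange of one whole ring for another, so this is the first sign that a single position on the ring can shift the number beyond the scatter. Set against the pyridin-2-yl ring, 2-hydroxy-4-methoxyphenyl gives an at least 25-fold lower number from compound 2 to compound 4 (1.40 log units; beyond the scatter), but this step can only be read as a minimum, since compound 2 gives a limit and not a number: the limit of > 100000 nM in this assay, at which 2 of the 4 values shown sit.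

On these data alone, it remains open whether the lower number is specific to methoxy or would also appear with an ethoxy group, a chlorine atom or a dimethylamino group on the same carbon, or with methoxy on another carbon of the ring. It is also open whether methoxy would still lower the number on a 4-methoxyphenyl ring that lacks the hydroxy group, and the compounds shown give no reason for the step.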